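The compounds below may be only part of what the source reports. "The series", "measured", "known", "first", "only" and "open" are said of these compounds alone.

In a functional assay on HCT-116 cells (Homo sapiens) for antiproliferative activity, read by MTT assay, with a stated time of 72 h (on this read-out lower numbers stand for stronger inhibition of growth and higher numbers for weaker inhibition of growth), compound 1 `Cn1nc(-c2ccnc(Nc3ccc(O)cc3)n2)c2ccccc21` gives 8430 nM. Among the three compounds measured so far it stands second highest: compound 2 `Cc1cccc(Nc2nccc(-c3nn(C)c4ccccc34)n2)c1` gives 9420 nM and compound 3 `Cn1nc(-c2ccnc(Nc3cccc(Cl)c3)n2)c2ccccc21` gives 6400 nM, so all three sit within the usual scatter of one another. The measured steps are small: a 1.1-fold higher number from compound 1 to compound 2 (0.05 log units; within the scatter), a 1.3-fold lower number from compound 1 to compound 3 (0.12 log units; within the scatter) and a 1.5-fold lower number from compound 2 to compound 3 (0.17 log units; within the scatter), each of them within the scatter.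

Compound 4 `CCn1nc(-c2ccnc(Nc3ccc(O)cc3)n2)c2ccccc21` differs from compound 1 only at the alkyl group on the ring nitrogen of the shared core: methyl in place of hydrogen on a saturated chain carbon bound to an aromatic nitrogen, which read one bond further out is methyl to ethyl. Among the measured compounds shown here, none of the measured steps alters this place; all of them concern the aryl group on the amino nitrogen, and none moved the number beyond the scatter. Nothing measured here speaks for a step beyond the scatter in this assay in either direction, so compound 4 is expected to sit close to compound 1, with a 1.0-fold lower number from compound 1 to compound 4 (0.00 log units; within the scatter). Compound 4 is therefore estimated at 8400 nM, within a range from 4000 nM to 18000 nM.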

Compound 4, concentration for 50% growth inhibition: 5290 nM
The estimate for compound 4 lay 1.6-fold (0.20 log units) above the measured number; the measured number falls inside the stated range.
By their numbers in this assay, from the lowest: compounds 4, 3, 1 and 2 (each within the scatter of the next).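

Compound 4 is the first compound shown to change the alkyl group on the ring nitrogen of the shared core rather than the aryl group on the amino nitrogen, and in this assay the change from methyl to ethyl gives a 1.6-fold lower number from compound 1 to compound 4 (0.20 log units; within the scatter) as its step. This place, on a saturated chain carbon bound to an aromatic nitrogen, thus joins the aryl group in showing no step beyond the scatter, though only for this one change with 4-hydroxyphenyl on the amino nitrogen. No measurement shown here offers an explanation for this result.

Going by these compounds, whether a longer chain such as propyl, or a chain ending in an amine or a carboxylic acid, would move the number beyond the scatter at this place remains open. Also open, on these data alone, is whether ethyl gives a similar step with 3-chlorophenyl or 3-methylphenyl on the amino nitrogen.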